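Working notes: nitro in place of methyl

The source may hold more compounds than are shown below. What is called first, only, known or untested is meant among the compounds shown, and "the series" means these compounds.

Compound 1 `N/C(=N\OS(=O)(=O)c1ccc([N+](=O)[O-])cc1)c1cccnc1` gives 85000 nM
Compound 2 `Cc1ccc(S(=O)(=O)O/N=C(\N)c2ccccn2)cc1` gives 80000 nM

In a functional assay for inhibition, read by spectrophotometry (on this read-out lower numbers stand for stronger inhibition and higher numbers for weaker inhibition), compound 2 stands level with compound 1, the two values lying within the scatter of each other. Compound 3 `N/C(=N\OS(=O)(=O)c1ccc([N+](=O)[O-])cc1)c1ccccn1` differs from compound 2 by nitro in place of methyl on an aromatic carbon, para to a large group (nitro in place of methyl on an aromatic carbon). Among the measured compounds shown here, no measured step covers this change. In this assay no step beyond the scatter is expected, as compound 1 also bears nitro and gives 85000 nM in the same range as compound 2. The estimate means a 1.1-fold lower number from compound 2 to compound 3 (0.03 log units; within the scatter) as the expected step. Compound 3 is expected at 75000 nM within an estimated range of 30000 nM to 180000 nM in this assay.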

Compound 3, half-maximal inhibitory concentration: 72000 nM
Beside the measured number, compound 3's estimate is 1.0-fold (0.02 log units) above it; the measured number falls inside the stated range.
By their numbers in this assay, from the lowest: compounds 3, 2 and 1 (each within the scatter of the next).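

In this assay, nitro in place of methyl on an aromatic carbon, para to a large group, gives a 1.1-fold lower number from compound 2 to compound 3 (0.05 log units; within the scatter), so the two groups stand level at this position. With nitro kept, pyridin-2-yl in place of pyridin-3-yl on a carbon with a double bond to nitrogen gives a 1.2-fold lower number from compound 1 to compound 3 (0.07 log units; within the scatter), so these two groups also stand level. No supporting data bear on why these values stand level.

Open, from the compounds shown here alone, is whether an amine or a carboxylic acid at the para position would stay in this range. Also open, going by these compounds, is whether an unsubstituted phenyl in place of the pyridine ring would do so.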